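This account rests on a few compounds, and the source may have more. Where it says the series, first, only, none or still open, it means among the compounds named here.

Compound 1 `c1ccc(Cc2nnc(-c3c[nH]c4ccccc34)o2)cc1` was examined in a functional assay on PC-3 cells (Homo sapiens) for cytotoxicity, read by MTT assay; on this read-out higher numbers stand for weaker inhibition and lower numbers for stronger inhibition. In this assay compound 1 gives > 1000000 nM, which is a limit of the assay and not a number. Compound 2 `COc1ccc(-c2nnc(-c3c[nH]c4ccccc34)o2)c(OC)c1OC` was examined in the same way. In this assay compound 2 gives > 1000000 nM, again a limit and not a number. Where compound 1 stands can therefore be told only as the limit of > 1000000 nM in this assay, at which 2 of the 2 values shown sit. For the measured compounds named here, no step between measured compounds is available, and no measured step gives a size for any change on this core.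

The unmeasured compound 3 `FC(F)(F)c1nnc(-c2c[nH]c3ccccc23)o1` differs from compound 1 in one place: trifluoromethyl in place of benzyl on an aromatic carbon. Going by the values given here, with no measured step to lean on, the expected step in this assay is a step that the limit leaves unreadable from compound 1 to compound 3, which amounts to none beyond the scatter, and it is expected that compound 3 will most likely return only a limit as compound 1 did. Compound 3 is estimated at 1500000 nM in this assay, with an expected range from 200000 nM to 10000000 nM.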

Compound 3, half-maximal inhibitory concentration: > 1000000 nM
Compound 3 was reported as a limit; the forecaster's own chance of this, stated with the estimate: 85%; the middle value is on the limit's open side.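

For the compounds shown here, no step from compound 1 to compound 3 can be read, since in this assay both compounds return only a limit, and the results stand as follows: the limit of > 1000000 nM in this assay, at which 3 of the 3 values shown sit. The compounds shown leave open how benzyl and trifluoromethyl compare in this assay and whether any change on the shared core would give a readable value there.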